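A few compounds are considered here, and "the series" means these few. Any claim that something is new, unique, unknown or untested is made for them only; others in the source may bear on it.

For the measured compounds named here, in a functional assay on PC-3 cells (Homo sapiens) for cytotoxicity, read by MTT assay, with a stated time of 48 h (on this read-out lower numbers stand for stronger inhibition and higher numbers for weaker inhibition), compound 3 (`COc1cc(-n2c(-c3ccc(Br)cc3)cn(C(C)=O)c2=O)cc(OC)c1OC`) gives 3100 nM and is the only compound with a number so far. Compound 1 (`COc1ccc(-c2c[nH]c(=O)n2-c2cc(OC)c(OC)c(OC)c2)cc1`) reads > 50000 nM and this is a limit of the assay. Compound 2 (`COc1ccc(-c2cn(C(=O)Nc3cc(OC)c(OC)c(OC)c3)c(=O)n2-c2cc(OC)c(OC)c(OC)c2)cc1OC`) carries a 3,4-dimethoxyphenyl and reads > 50000 nM and this too is a limit. Compound 4 (`COc1ccc(-c2cn(C(C)=O)c(=O)n2-c2cc(OC)c(OC)c(OC)c2)cc1OC`) keeps the acetyl group of compound 3 and takes 3,4-dimethoxyphenyl in place of 4-bromophenyl on an aromatic carbon. Going by the values given here, no measured step isolates this change. Weaker inhibition is expected in this assay on the sole evidence of compound 2 with its limit of > 50000 nM as the other compound bearing this group. The expected move is a 2.9-fold higher number from compound 3 to compound 4 (0.46 log units; beyond the scatter) towards weaker inhibition. Compound 4 is estimated at 9000 nM in this assay (2000 nM to 40000 nM).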

Compound 4, half-maximal inhibitory concentration: > 50000 nM
Compound 4: only a limit was reported; the forecaster's own chance of this, stated with the estimate: 25%; middle value at least 5.5-fold (0.74 log units) from the limit.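

Replacing 4-bromophenyl with 3,4-dimethoxyphenyl on this aromatic carbon, with the acetyl group kept, gives an at least 16-fold higher number from compound 3 to compound 4 (1.20 log units; beyond the scatter) in this assay. For the compounds shown here, this is the first single-place comparison, and it shows that the acetyl group alone does not secure a numerical value here: the 4-bromophenyl group is needed alongside it. The full size of the step cannot be read, since the value for compound 4 is a limit: the limit of > 50000 nM in this assay, at which 3 of the 4 values shown sit.

Still open, from the compounds shown here alone, is whether the loss follows from losing the bromine or from gaining the two methoxy groups. An unsubstituted phenyl or a 4-chlorophenyl group at this carbon would bear on that question.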